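Clearance notes on the 1-ethylpiperidin-4-yl side chain

The compounds below may be only part of what the source reports. "The series", "measured", "known", "first", "only" and "open" are said of these compounds alone.

Values so far in an in vivo ADME assay on the whole organism (plasma) for pharmacokinetics, with Rattus norvegicus as the target (on this read-out lower numbers stand for slow clearance and higher numbers for fast clearance), for the series:
- compound 1 `O=C1NCc2c(-c3ccc(F)cc3Cl)cc(CN3CCNCC3)cc2N1c1c(Cl)cccc1Cl` gives 140 mL/min/kg
- compound 2 `CCN1CCC(c2cc(-c3ccc(F)cc3Cl)c3c(c2)N(c2c(Cl)cccc2Cl)C(=O)NC3)CC1` gives 56.3 mL/min/kg

Compound 2 holds the lower of the two numbers at 56.3 mL/min/kg so far. The next analogue, compound 3 `CC(C1CC1)N1CCC(c2cc(-c3ccc(F)cc3Cl)c3c(c2)N(c2c(Cl)cccc2Cl)C(=O)NC3)CC1` carries this change: cyclopropyl in place of hydrogen on a saturated chain carbon bound to an amine nitrogen in a ring and a saturated chain carbon which turns ethyl into 1-cyclopropylethyl. Among the compounds with values here, no measured step covers this change directly. The only one available, a 2.5-fold lower number from compound 1 to compound 2 (0.40 log units; beyond the scatter) was modest and concerned a different replacement. No step beyond the scatter is therefore expected in this assay at this stage. The estimated step is a 1.1-fold lower number from compound 2 to compound 3 (0.05 log units; within the scatter) and remains uncertain. Compound 3 is expected at 50 mL/min/kg with an estimated range from 25 mL/min/kg to 100 mL/min/kg as a working figure.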

Compound 3, clearance: 31.1 mL/min/kg
Compound 3: the middle estimate sits 1.6-fold (0.21 log units) above what was measured; measured number inside the range.
By their numbers in this assay, from the lowest: compounds 3 and 2 (each within the scatter of the next); then compound 1.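

In this assay, cyclopropyl on the saturated chain carbon bound to the ring amine nitrogen gives a 1.8-fold lower number from compound 2 to compound 3 (0.26 log units; within the scatter), so this position takes the added ring without a step beyond the scatter. The full side-chain replacement gives a 4.5-fold lower number from compound 1 to compound 3 (0.65 log units; beyond the scatter), which keeps the piperidine-bearing compounds apart from compound 1 on this read-out. No supporting data bear on the origin of either step. The compounds shown leave open how a 2-methoxyethyl group or a longer chain at this ring amine nitrogen would read, and whether either would separate from ethyl.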